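This account rests on a few compounds, and the source may have more. Where it says the series, first, only, none or still open, it means among the compounds named here.

Of the compounds shown here, two have been read so far in an ADME assay on CHO cells (Cricetulus griseus) for cytotoxicity; on this read-out higher numbers stand for weaker inhibition and lower numbers for stronger inhibition. Compound 1 `Oc1ccc(CNc2cc(Nc3cnccn3)nc(-c3ccnc(N4CCNCC4)c3)c2)cc1` gives > 20000 nM, which is a limit of the assay and not a number. Compound 2 `O=C(Cc1cccnc1)Nc1cc(Nc2cnccn2)nc(-c2ccnc(N3CCNCC3)c2)c1` gives > 20000 nM, which is likewise a limit. Compound 2 therefore has no exact position, and the whole record so far is the limit of > 20000 nM in this assay, at which 2 of the 2 values shown sit. Among the measured compounds shown here, the one measured change, ((pyridin-3-yl)methyl)carbonyl in place of 4-hydroxybenzyl on a nitrogen on an aromatic ring, is a step that the two limits leave unreadable from compound 1 to compound 2. It gives no size to carry forward, though two different groups at this nitrogen both ended at the limit.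

Compound 3 `CNc1cc(Nc2cnccn2)nc(-c2ccnc(N3CCNCC3)c2)c1` changes the same place again, with methyl in place of ((pyridin-3-yl)methyl)carbonyl on a nitrogen on an aromatic ring. This is a large cut in the group, but with only limits to go on, no clear shift in this assay is expected in either direction. The expected change is a number no higher from compound 2 to compound 3 (the limit leaves the size open). A further limit is the most likely report. For compound 3 the estimated value is 20000 nM, with an expected range of 8000 nM to 40000 nM.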

Compound 3, half-maximal inhibitory concentration: > 20000 nM
Compound 3: no number, only a limit; the forecaster's own chance of this, stated with the estimate: 80%; the middle value sits exactly at the limit.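

Among the compounds shown here, compound 1, compound 2 and compound 3 all end at a limit rather than a number in this assay, so no step among them can be read. The record now reads: the limit of > 20000 nM in this assay, at which 3 of the 3 values shown sit.

The compounds shown leave open how far each one lies from that limit, and whether any group on this nitrogen would give a readable number.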